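The source may report more compounds than this note shows. Statements on the series, on what has been measured and on what is new or still open speak of the compounds shown alone.

Measured compounds in a functional assay on SH-SY5Y cells (Homo sapiens) for cytotoxicity, tested at 300 nM; on this read-out higher numbers stand for a weaker effect at the one concentration tested and lower numbers for a stronger effect:

Compound 1 `N#CCCCc1cn(-c2ccncc2)nn1` gives 87.8%.
Compound 2 `O=C(CCCCCCn1cc(-c2cccnc2)nn1)Nc1ccccc1Cc1ccccc1` gives 86.1%.
Compound 3 `O=C(CCCCCCCCn1cc(-c2cccnc2)nn1)Nc1ccccc1Oc1ccccc1` gives 79.5%.

All three numbers sit close together. Compound 2 holds the second highest of the three numbers in this assay; its nearest neighbour is compound 1, whose number lies only a little higher and within the usual scatter of repeated measurements, and its furthest neighbour is compound 3, whose number lies somewhat lower but still within that scatter. On these numbers, none of the three compounds can be set apart from the others.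

The next compound, compound 4 `COc1ccccc1NC(=O)CCCCCCn1cc(-c2cccnc2)nn1`, has not yet been measured in this assay. It differs from compound 2 in one place: methoxy in place of benzyl on an aromatic carbon. Within the data shown here, no step between two measured compounds shows how such a change plays out here, so there is nothing in the measured numbers to suggest a movement beyond the scatter.

The expectation for compound 4 in this assay is therefore a number close to that of compound 2, with a step of a number 1.1 percentage points lower from compound 2 to compound 4 (within the scatter), which is not expected to reach beyond the scatter. The estimate for compound 4 is 85%, with a range from 72% to 96%.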

Compound 4, a percentage reported as activity, at one concentration (the size of the read-out at that concentration, not a potency): 87.9%
Beside the measured number, compound 4's estimate is 2.9 percentage points below it; low and high end bracket the measured number.
By their numbers in this assay, from the lowest: compounds 3, 2, 1 and 4 (each within the scatter of the next).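

In this assay, methoxy in place of benzyl on an aromatic carbon, ortho to a large group, gives a number 1.8 percentage points higher from compound 2 to compound 4 (within the scatter) and so leaves the two numbers indistinguishable. Among these compounds, this is the first measured pair that differs in one place, and it shows that a much smaller group, with no ring and with a hydrogen-bond acceptor, can stand at this position without the read-out moving beyond the scatter. No available measurement offers a reason for this result.

Going by these compounds, whether an amine or a carboxylic acid at this position would also keep the number within the scatter of compound 2 remains open. Also open, on these data alone, is whether the same swap would read alike on a longer chain, and at other concentrations, since one concentration gives no measure of potency.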